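The source may report more compounds than this note shows. Statements on the series, on what has been measured and on what is new or still open speak of the compounds shown alone.

Compound 1 `COc1ccccc1NC(=O)C1CCN(C/C=C/c2ccccc2)CC1`: 71200 nM
Compound 2 `CN1CCN(c2ccc(NC(=O)C3CCN(C/C=C/c4ccccc4)CC3)cc2)CC1`: 14000 nM

In a functional assay on MGC-803 cells (Homo sapiens) for inhibition, read by MTT assay, with a stated time of 72 h (a higher number here means a weaker inhibitor, a lower number a stronger inhibitor), compound 1 gives 71200 nM, the higher of the two numbers, so it is the weaker inhibitor of this pair, and the gap to compound 2 lies beyond the scatter. Compound 3 `O=C(Nc1nccs1)C1CCN(C/C=C/c2ccccc2)CC1` has not yet been measured. It carries 1,3-thiazol-2-yl in place of 2-methoxyphenyl on an amide-type nitrogen. Within the data shown here, no measured pair shows this swap alone, so only a slight shift toward a lower number, not beyond the scatter, is expected. The expected change is a 1.6-fold lower number from compound 1 to compound 3 (0.20 log units; within the scatter). For compound 3 the estimated value is 45000 nM, with an expected range of 14000 nM to 120000 nM.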

Compound 3, half-maximal inhibitory concentration: 16400 nM
Compound 3: middle estimate off by 2.7-fold (0.44 log units), on the high side, within the range that was stated.
By their numbers in this assay, from the lowest: compounds 2 and 3 (each within the scatter of the next); then compound 1.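

On the amide-type nitrogen of the shared core, placing 1,3-thiazol-2-yl in place of 2-methoxyphenyl gives a 4.3-fold lower number from compound 1 to compound 3 (0.64 log units; beyond the scatter) in this assay. Among these compounds, this is the only single-place comparison here, and it shows that the group on this nitrogen can move the number beyond the usual scatter. Nothing measured here explains the step.

From the compounds shown here alone, it remains open whether the change comes from the five-membered ring with its sulfur and nitrogen or simply from losing 2-methoxyphenyl. Plain phenyl or pyridine on the same nitrogen would help separate these two readings.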